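A few compounds are considered here, and "the series" means these few. Any claim that something is new, unique, unknown or untested is made for them only; others in the source may bear on it.

Measured in a functional assay on A549 cells (Homo sapiens) for antiproliferative activity, read by MTT assay, with a stated time of 72 h; on this read-out lower numbers stand for stronger inhibition and higher numbers for weaker inhibition:
compound 1 `CCN(CC)CCCOc1cc2ncnc(Nc3ccc(C#N)cc3)c2cc1OC`: 50600 nM
compound 2 `COc1cc2c(Nc3ccc(C#N)cc3)ncnc2cc1OCCCN1CCC(CO)CC1`: > 100000 nM
compound 3 `COc1cc2c(Nc3ccc(C#N)cc3)ncnc2cc1OCCCN1CCC(N2CCCCC2)CC1`: 30700 nM

The entry for compound 2 is a limit, not a number. Only compound 1 and compound 3 give numbers, and these lie within the scatter of each other: a 1.6-fold lower number from compound 1 to compound 3 (0.22 log units; within the scatter). Within the data shown here, the one step clearly beyond the scatter is an at least 3.2-fold lower number from compound 2 to compound 3 (0.51 log units; beyond the scatter), and the floor of an at least 1.9-fold higher number from compound 1 to compound 2 (0.29 log units; that floor lies within the scatter) stays within it.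

Compound 4 `CCN1CCN(CCCOc2cc3ncnc(Nc4ccc(C#N)cc4)c3cc2OC)CC1` carries 4-ethylpiperazin-1-yl in place of 4-(piperidin-1-yl)piperidin-1-yl on the same chain carbon: 4-ethylpiperazin-1-yl in place of 4-(piperidin-1-yl)piperidin-1-yl on a saturated chain carbon, three bonds along the chain from an oxygen on an aromatic ring. Like compound 3, it has no hydroxymethyl, so the closest guide is the swap from diethylamino, a 1.6-fold lower number from compound 1 to compound 3 (0.22 log units; within the scatter), and no step beyond the scatter is expected in this assay.

The expected step is a 1.3-fold higher number from compound 3 to compound 4 (0.11 log units; within the scatter).

For compound 4 the estimate is 40000 nM, with an expected range of 16000 nM to 100000 nM.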

Compound 4, half-maximal inhibitory concentration: 16000 nM
The estimate for compound 4 lay 2.5-fold (0.40 log units) above the measured number; the measured number falls inside the stated range.
By their numbers in this assay, from the lowest: compounds 4, 3 and 1 (each within the scatter of the next, the first and the last beyond it). At a limit, above all of these: compound 2.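

In this assay, among these compounds, 4-ethylpiperazin-1-yl gives the first step between two numbers that lies beyond the scatter (a 3.2-fold lower number from compound 1 to compound 4 (0.50 log units; beyond the scatter)). Exchanging 4-(piperidin-1-yl)piperidin-1-yl for it stays within the scatter (a 1.9-fold lower number from compound 3 to compound 4 (0.28 log units; within the scatter)), so the second saturated ring is not needed to hold this level. The step from the hydroxymethyl compound is open-ended (an at least 6.2-fold lower number from compound 2 to compound 4 (0.79 log units; beyond the scatter)), as compound 2 stands at a limit: the limit of > 100000 nM in this assay, at which 1 of the 4 values shown sits.

Going by these compounds, whether a morpholin-4-yl group or a longer chain at this place would give a lower number stays open. So does the effect of a hydroxymethyl group on any other amine.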